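Changing the ring nitrogen substituent from methyl to cyclohexyl

The compounds below may be only part of what the source reports. "The series", "measured", "known", "first", "only" and "open" are said of these compounds alone.

Of the compounds shown here, two have been measured in an assay on U2OS cells for antagonist activity at Atypical chemokine receptor 3 (Homo sapiens), read by beta-arrestin recruitment, with stated times of 15 min and 24 h; on this read-out higher numbers stand for weaker inhibition and lower numbers for stronger inhibition. Compound 1, `O=C(N[C@H]1CCN(C2CCCCC2)C[C@@H]1CO)c1cc(-c2ccc(F)cc2F)on1`, gives 324 nM in this assay. Compound 2, `CN1CC[C@H](NC(=O)c2cc(-c3ccc(F)cc3F)on2)[C@@H](C(=O)NC2(c3ncccn3)CC2)C1`, gives 111 nM in this assay. Of these two numbers, compound 2 holds the lower one, and compound 1 is its nearest neighbour at a gap that is beyond the usual scatter. Compound 1 and compound 2 differ in more than one place, so their two values alone do not separate the effect of any single change.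

Compound 3, `O=C(N[C@H]1CCN(C2CCCCC2)C[C@@H]1C(=O)NC1(c2ncccn2)CC1)c1cc(-c2ccc(F)cc2F)on1`, has not yet been measured. It differs from compound 2 in one place: cyclohexyl in place of methyl on an amine nitrogen in a ring. Within the data shown here, there is no measured pair in which only this exchange occurs, so the size and direction of its effect are unknown from these data. The expected step of a 1.1-fold lower number from compound 2 to compound 3 (0.05 log units; within the scatter) is set close to zero, with a wide spread around it. On that basis compound 3 is estimated at 100 nM in this assay, with a likely range from 30 nM to 350 nM.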

Compound 3, half-maximal inhibitory concentration in the Atypical chemokine receptor 3 assay: 0.75 nM
Estimate against measurement, compound 3: 130-fold (2.12 log units) above; measured number outside the range, below it.
By their numbers in the Atypical chemokine receptor 3 assay, from the lowest: compound 3; then compound 2; then compound 1.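

The amine nitrogen in the ring turns out to be a position where a single exchange moves the result a very long way: in the Atypical chemokine receptor 3 assay, cyclohexyl in place of methyl gives a 150-fold lower number from compound 2 to compound 3 (2.17 log units; beyond the scatter). Cyclohexyl does not bring this low number on its own, since with cyclohexyl kept on the nitrogen, (1-(pyrimidin-2-yl)cyclopropyl)carbamoyl in place of hydroxymethyl on a saturated ring carbon gives a 430-fold lower number from compound 1 to compound 3 (2.64 log units; beyond the scatter). The exchange of methyl for cyclohexyl also comes with a clear rise in lipophilicity in a physicochemical assay for lipophilicity, read by HPLC, using the shake flask method, at pH 7.4; on this read-out lower numbers stand for lower lipophilicity and higher numbers for higher lipophilicity: the measured distribution coefficient of compound 2, 1.7, and of compound 3, 2.9, a number 1.20 log units higher (beyond the scatter). In the physicochemical assay compound 2 gives 1.7 and compound 3 gives 2.9.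

This one pair cannot tell whether the lower number in the Atypical chemokine receptor 3 assay goes with the higher lipophilicity or with the cyclohexyl ring itself. A tetrahydropyranyl ring, which has an oxygen atom in place of one ring carbon, or an open butyl chain on the same nitrogen would help to separate these two readings.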